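The compounds below may be only part of what the source reports. "The series", "measured", "known", "first", "only" and "open" are said of these compounds alone.

Three compounds built on one shared core were tested in an assay on CHO cells for displacement of a labelled ligand from adenosine receptor A3 (Homo sapiens), read by scintillation counting, with a stated time of 45 min, in the presence of a further agent that is not named here; a lower number here means a stronger inhibitor, a higher number a weaker inhibitor. Compound 1 `CCCn1c(=O)c2[nH]c(-c3ccc(S(=O)(=O)N4CCN(c5ccc(Cl)cc5)CC4)cc3)nc2n(CC)c1=O` gives > 1000 nM, which is a limit of the assay rather than a number. Compound 2 `CCCn1c(=O)[nH]c2nc(-c3ccc(S(=O)(=O)N4CCN(c5cccc(F)c5)CC4)cc3)[nH]c2c1=O` gives > 1000 nM, again only a limit. Compound 3 `CCCn1c(=O)[nH]c2nc(-c3ccc(S(=O)(=O)N4CCN(c5ccccc5)C(C)C4)cc3)[nH]c2c1=O` gives > 1000 nM, also a limit. Among the measured compounds shown here, compound 2 therefore stands nowhere apart from its two companions: all three sit at the limit of > 1000 nM in this assay, at which 3 of the 3 values shown sit, so no order of strength among them can be read, and no measured step between any two of them exists.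

Compound 4 `CCCn1c(=O)[nH]c2nc(-c3ccc(S(=O)(=O)N4CCN(c5ccc(I)cc5)CC4)cc3)[nH]c2c1=O` differs from compound 2 in a single place: 4-iodophenyl in place of 3-fluorophenyl on an amine nitrogen in a ring. For the measured compounds named here, with no measured step on record, the size of this change can only be expected, not read off. Since compound 2 reaches only > 1000 nM, nothing suggests the new compound will cross into measurable territory. The step from compound 2 to compound 4 is estimated as a step that the limit leaves unreadable from compound 2 to compound 4, no change beyond the scatter. Compound 4 is expected to give roughly 3000 nM, within a range from 1000 nM to 15000 nM, most likely reported again only as a limit.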

Compound 4, inhibition constant: > 1000 nM
Compound 4 ended at the assay's limit; the forecaster's own chance of this, stated with the estimate: 75%; the middle value is on the limit's open side.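

Among the compounds shown here, compound 2 and compound 4 both sit at a limit of the assay rather than at a number, so no step between them can be read. In this assay the compounds shown leave open how strong each one truly is, and which change on the shared core, if any, would give a measurable value.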